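Permeability of compound 3 judged from its two neighbours

A few compounds are considered here, and "the series" means these few. Any claim that something is new, unique, unknown or untested is made for them only; others in the source may bear on it.

Of the compounds shown here, two of a shared core have been measured so far. Compound 1 `CNC(=O)c1cc(C(=O)N[C@H]2CC[C@H](O)CC2)c([C@@H](C)c2cccc(F)c2)o1` gives 73 nm/s in an ADME assay for permeability; a higher number here means that the compound crosses the layer faster, a lower number that the compound crosses the layer more slowly. Compound 2 `CNC(=O)c1cc(C(=O)N[C@H]2CC[C@H](O)CC2)c([C@@H](C)c2cccc(OC)c2)o1` gives 44 nm/s in this assay, the lowest of the two numbers recorded, its nearest neighbour being compound 1; the gap between them is a 1.7-fold lower number from compound 1 to compound 2 (0.22 log units; within the scatter), which arose from methoxy in place of fluoro on an aromatic carbon.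

Compound 3 `CNC(=O)c1cc(C(=O)N[C@H]2CC[C@H](O)CC2)c([C@@H](C)c2ccc(C)cc2)o1` has not yet been measured in this assay. Relative to compound 2 the change is 4-methylphenyl in place of 3-methoxyphenyl on a saturated chain carbon bound to an aromatic carbon and a saturated chain carbon. Within the data shown here, only one measured step concerns the same ring, the step from compound 1 to compound 2 of a 1.7-fold lower number from compound 1 to compound 2 (0.22 log units; within the scatter), and it stayed within the scatter. Among the measured compounds shown here, no measured step swaps a methoxy for a methyl, so the new change is judged only from the quiet behaviour of that ring so far. Accordingly the step of a 1.4-fold higher number from compound 2 to compound 3 (0.13 log units; within the scatter) is expected to stay within the scatter. Compound 3 is therefore estimated at 60 nm/s, with a range from 35 nm/s to 110 nm/s.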

Compound 3, apparent permeability in the ADME assay: 108 nm/s
The estimate for compound 3 lay 1.8-fold (0.26 log units) below the measured number; the range from low to high includes it.
By their numbers in the ADME assay, from the lowest: compounds 2, 1 and 3 (each within the scatter of the next, the first and the last beyond it).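

At the saturated chain carbon bound to an aromatic carbon and a saturated chain carbon, the choice of ring substituent now gives a step beyond the scatter in the ADME assay: 4-methylphenyl in place of 3-methoxyphenyl gives a 2.5-fold higher number from compound 2 to compound 3 (0.39 log units; beyond the scatter), whereas 4-methylphenyl in place of 3-fluorophenyl gives only a 1.5-fold higher number from compound 1 to compound 3 (0.17 log units; within the scatter), so this position is not as quiet as the earlier pair suggested, and the clear separation holds only against 3-methoxyphenyl. In a physicochemical assay for solubility, measured as kinetic solubility (a higher number here means a more soluble compound, a lower number a less soluble compound), compound 2 gives >= 113 ug/mL, which is a limit of the assay. In the physicochemical assay compound 3 gives >= 245 ug/mL, which is also a limit, and the step in this read-out cannot be read.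

Nothing available explains the difference in the ADME assay. The step from 3-methoxyphenyl to 4-methylphenyl changes both the substituent and its place on the ring, so the compounds shown do not separate these two changes, and they leave open how the ADME assay would respond to an amine or a carboxylic acid on that ring.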